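The source may hold more compounds than are shown below. What is called first, only, known or untested is meant among the compounds shown, and "the series" means these compounds.

Working notes on the series. In a functional assay on MCF7 cells (Homo sapiens) for antiproliferative activity, read by MTT assay, with a stated time of 72 h (on this read-out lower numbers stand for stronger inhibition and higher numbers for weaker inhibition), compound 1 (`CCOc1ccc(-c2ccc3ncn(-c4cc(OC)c(OC)c(OC)c4)c3c2)cc1`) gives 1710 nM, and compound 2 (`COc1cc(-n2cnc3ccc(-c4ccc(F)cc4)cc32)cc(OC)c1OC`) gives 1770 nM. These two numbers lie within the scatter of each other, so compound 2 stands level with compound 1 and has no rank of its own.

Compound 3 (`COc1cccc(-c2ccc3ncn(-c4cc(OC)c(OC)c(OC)c4)c3c2)c1`) has not yet been measured. It differs from compound 2 by 3-methoxyphenyl in place of 4-fluorophenyl on an aromatic carbon.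

Among the compounds with values here, only one measured step bears on this change: a 1.0-fold higher number from compound 1 to compound 2 (0.01 log units; within the scatter), with fluoro in place of ethoxy on an aromatic carbon. That step stays within the scatter, which gives no sign that the swap of these groups moves the number. Within the data shown here, it is thin evidence, however, as no measured compound carries a 3-methoxyphenyl group. No step beyond the scatter is therefore expected in this assay, and no direction is favoured, though the range is kept wide.

The expected change is a 1.0-fold lower number from compound 2 to compound 3 (0.02 log units; within the scatter). For compound 3 the estimated value is 1700 nM, with an expected range of 600 nM to 5000 nM.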

Compound 3, half-maximal inhibitory concentration: 1610 nM
For compound 3 the middle estimate is 1.1-fold (0.02 log units) above the measured one; the range from low to high includes it.
By their numbers in this assay, from the lowest: compounds 3, 1 and 2 (each within the scatter of the next).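

In this assay, within the data shown here, the earlier compounds covered only 4-ethoxyphenyl and 4-fluorophenyl on this aromatic carbon, and the new 3-methoxyphenyl group gives a 1.1-fold lower number from compound 2 to compound 3 (0.04 log units; within the scatter) and a 1.1-fold lower number from compound 1 to compound 3 (0.03 log units; within the scatter). Across compounds 1, 2 and 3, therefore, neither the exchange of these substituents nor the shift from a group named at 4 to one named at 3 separates the numbers, so this place tolerates all three aryl groups alike in this read-out. No measured data on the compounds shown offer any account of this level result.

The compounds shown leave open whether an amine, a carboxylic acid or a longer chain on this phenyl ring, or a group other than a phenyl ring at this carbon, would produce a step beyond the scatter. On these data alone, the trimethoxyphenyl group and the rest of the shared core are the same in all three compounds, so what changes there would do in this assay also remains open.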